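Carbamoyl position on the benzoyl group: compound 3

A few compounds are considered here, and "the series" means these few. Any claim that something is new, unique, unknown or untested is made for them only; others in the source may bear on it.

Measured so far:
compound 1, `O=C(c1ccccc1)N1CCC(N(C2CC2)S(=O)(=O)c2cccc(C(F)(F)F)c2)CC1` — 42%
compound 2, `NC(=O)c1cccc(C(=O)N2CCC(N(C3CC3)S(=O)(=O)c3cccc(C(F)(F)F)c3)CC2)c1` — 0%

In an assay on HEK293 cells for inhibition of Voltage-dependent N-type calcium channel subunit alpha-1B (Homo sapiens), read by FLIPR and calcium flux, tested at 1 uM (a higher number here means more inhibition at the concentration tested (going by the name of the read-out), a lower number less inhibition), compound 1 gives 42%. Among the compounds with values here, compound 2 carries a carbamoyl on the aromatic ring of the benzoyl group and in this assay compound 2 gives 0%, the lowest of the two numbers so far; the only other number, that of compound 1, lies above it by a step beyond the scatter, a number 42 percentage points lower from compound 1 to compound 2 (beyond the scatter).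

Compound 3 is `NC(=O)c1ccc(C(=O)N2CCC(N(C3CC3)S(=O)(=O)c3cccc(C(F)(F)F)c3)CC2)cc1`. Its difference from compound 2 is a change of place, not of atoms: 4-carbamoylphenyl in place of 3-carbamoylphenyl on a carbonyl carbon.

Within the data shown here, only one measured step exists, and it bears on this change indirectly: adding a carbamoyl to the ring of compound 1 removed all inhibition, a number 42 percentage points lower from compound 1 to compound 2 (beyond the scatter). Among the measured compounds shown here, no pair shows whether moving that carbamoyl to the 4-position restores anything. With compound 2 already at the floor of the read-out, the carbamoyl is expected to keep inhibition low wherever it sits on this ring, so no step beyond the scatter is expected, a number 5 percentage points higher from compound 2 to compound 3 (within the scatter). Compound 3 is therefore estimated at 5%, within 0% to 25%.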

Compound 3, a percentage reported as inhibition, at one concentration (the size of the read-out at that concentration, not a potency): 12%
Estimate against measurement, compound 3: 7 percentage points below, and the stated range covers the measured number.
By their numbers in this assay, from the lowest: compound 2; then compound 3; then compound 1.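

In this assay the place of the carbamoyl on the benzoyl ring matters: 4-carbamoylphenyl in place of 3-carbamoylphenyl on a carbonyl carbon gives a number 12 percentage points higher from compound 2 to compound 3 (beyond the scatter) and so, with the atoms unchanged, the two arrangements do not read the same. The recovery is only partial, as the carbamoyl at its new place still gives a number 30 percentage points lower from compound 1 to compound 3 (beyond the scatter) and leaves compound 1 the highest of the three, so both placings on this ring cost inhibition against the plain benzoyl group. No measurement at hand accounts for the effect of moving the carbamoyl on the read-out.

The compounds shown leave open whether this loss belongs to the carbamoyl itself or would also follow from another group in its place on the ring, such as a nitrile, a carboxylic acid, an aminomethyl or a methyl ester. They also leave open how the gap among these three compounds would look as a potency, since the read-out here is a percentage at a single concentration.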